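A level pair and an untested side chain

The source may hold more compounds than are shown below. What is called first, only, known or untested is meant among the compounds shown, and "the series" means these compounds.

Measured in a functional assay on KBVIN cells (Homo sapiens) for antiproliferative activity, read by sulforhodamine B assay, with a stated time of 3 days; on this read-out lower numbers stand for stronger inhibition of growth and higher numbers for weaker inhibition of growth:
Compound 1 `O=C(Nc1ccccn1)c1cccc(Nc2ncc(F)c(Nc3ccc(F)cc3)n2)c1` gives 13700 nM
Compound 2 `Cn1ccnc1NC(=O)c1cccc(Nc2ncc(F)c(Nc3ccc(F)cc3)n2)c1` gives 13100 nM

Compound 2 stands level with compound 1 within the scatter. Compound 3 `CN(C)CC(=O)Nc1cccc(Nc2ncc(F)c(Nc3ccc(F)cc3)n2)c1` has not been measured yet. The change is (((dimethylamino)methyl)carbonyl)amino in place of (1-methyl-1H-imidazol-2-yl)carbamoyl on an aromatic carbon, on an aromatic carbon of a six-membered aromatic ring of carbon only. Going by the values given here, one measured step bears on this, and only loosely: 1-methyl-1H-imidazol-2-yl in place of pyridin-2-yl on an amide-type nitrogen gave a 1.0-fold lower number from compound 1 to compound 2 (0.02 log units; within the scatter). Among the compounds with values here, no measured compound carries the entering group, so no shift beyond the scatter is expected, though the range stays wide. The expected change is a 1.2-fold lower number from compound 2 to compound 3 (0.08 log units; within the scatter). For compound 3 the estimate in this assay is 11000 nM, with an expected range of 3500 nM to 32000 nM.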

Compound 3, concentration for 50% growth inhibition: 1810 nM
Estimate against measurement, compound 3: 6.1-fold (0.78 log units) above; the measured number lies below the stated range.
By their numbers in this assay, from the lowest: compound 3; then compounds 2 and 1 (each within the scatter of the next).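

In this assay putting (((dimethylamino)methyl)carbonyl)amino on this aromatic carbon brings a 7.2-fold lower number from compound 2 to compound 3 (0.86 log units; beyond the scatter) and a 7.6-fold lower number from compound 1 to compound 3 (0.88 log units; beyond the scatter) when it replaces the (pyridin-2-yl)carbamoyl group instead. The group on this carbon therefore matters to growth inhibition, which the exchange of one ring for another on the amide nitrogen, level within the scatter, could not show. Nothing measured here says why the number falls.

The compounds shown leave open which part of the entering group carries the step. A morpholine or a longer chain in place of the dimethylamino group would test that.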